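The compounds below may be only part of what the source reports. "The series", "measured", "known", "first", "only" and "open" are said of these compounds alone.

Within the data shown here, in a functional assay on Caco-2 cells (Homo sapiens), read by MTT assay, with a stated time of 48 h (on this read-out higher numbers stand for weaker inhibition and lower numbers for stronger inhibition), compound 3 `CCn1c(C(=O)N(C)CC(=O)O)ccc1C(CC)(CC)c1ccc(OCC(=O)C(C)(C)C)c(C)c1` gives 35900 nM, the highest of the three numbers so far, against compound 1 `CCN(CC)CCNC(=O)c1ccc(C(CC)(CC)c2ccc(OCC(O)C(C)(C)C)c(C)c2)n1CC` at 2310 nM and compound 2 `CCn1c(C(=O)N(CCC#N)CCC#N)ccc1C(CC)(CC)c1ccc(OCC(O)C(C)(C)C)c(C)c1` at 7100 nM. Compound 4 `CCn1c(C(=O)N(C)CC(=O)O)ccc1C(CC)(CC)c1ccc(OCC(O)C(C)(C)C)c(C)c1` differs from compound 3 by a single change: 1-hydroxy-2,2-dimethylpropyl in place of (tert-butyl)carbonyl on a saturated chain carbon bound to an oxygen on an aromatic ring. The 2-hydroxy-3,3-dimethylbutoxy group of compound 4 also occurs in compound 1 and compound 2, while only compound 3 carries the ((tert-butyl)carbonyl)methoxy group. Among the measured compounds shown here, no measured step covers this change. The one available, a 3.1-fold higher number from compound 1 to compound 2 (0.49 log units; beyond the scatter), is a modest step at a different place, on a carbonyl carbon, and serves only as a guide to size. Compound 3 also differs from compound 1 and compound 2 in the group on that carbonyl carbon, so their values do not isolate the change. A modest move towards a lower number is expected, with a 2.0-fold lower number from compound 3 to compound 4 (0.30 log units; within the scatter) as the estimated step. For compound 4 the estimated value is 18000 nM, with an expected range of 6000 nM to 40000 nM.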

Compound 4, half-maximal inhibitory concentration: 31900 nM
Beside the measured number, compound 4's estimate is 1.8-fold (0.25 log units) below it; the range from low to high includes it.
By their numbers in this assay, from the lowest: compound 1; then compound 2; then compounds 4 and 3 (each within the scatter of the next).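

In this assay, with the (carboxymethyl)(methyl)amino group held fixed on the carbonyl carbon, 1-hydroxy-2,2-dimethylpropyl in place of (tert-butyl)carbonyl gives a 1.1-fold lower number from compound 3 to compound 4 (0.05 log units; within the scatter), so the two groups cannot be told apart at this position on this background. With the 2-hydroxy-3,3-dimethylbutoxy group now shared, the group on the carbonyl carbon separates the compounds, giving a 4.5-fold higher number from compound 2 to compound 4 (0.65 log units; beyond the scatter) and a larger 14-fold higher number from compound 1 to compound 4 (1.14 log units; beyond the scatter). No measurement at hand gives a reason for either result.

From the compounds shown here alone, whether (tert-butyl)carbonyl and 1-hydroxy-2,2-dimethylpropyl also match with the carbonyl groups of compound 1 and compound 2 remains open. So does the effect of an amine or a longer chain in place of 1-hydroxy-2,2-dimethylpropyl.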